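Swapping Bromine for Iodine on a Calpain Inhibitor

This account rests on a few compounds, and the source may have more. Where it says the series, first, only, none or still open, it means among the compounds named here.

Three compounds have been measured:

Compound 1, `O=C(O)/C(S)=C/c1c[nH]c2cc(Br)ccc12`, gives 7 nM in an assay on isolated protein for inhibition of Calpain-1 catalytic subunit (Sus scrofa), read by FRET; a lower number here means a stronger inhibitor, a higher number a weaker inhibitor.
Compound 2, `O=C(O)/C(S)=C/c1c[nH]c2ccc(F)cc12`, gives 800 nM in this assay.
Compound 3, `O=C(O)/C(S)=C/c1cccc(F)c1`, gives 19000 nM in this assay.

Compound 1 stands at the lowest number of the three. Compound 2 is the nearest to it, yet the gap between them lies well beyond the scatter of repeated measurements, and the gap to compound 3 is wider still. No two of these compounds differ in just one place, so no single-point step between measured compounds can be read off.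

Compound 4, `O=C(O)/C(S)=C/c1c[nH]c2cc(I)ccc12`, is built from compound 1 by one change: iodo in place of bromo on an aromatic carbon. Bromine and iodine are close neighbours among the halogens, and the rest of the molecule is untouched, so only a small step is expected from this exchange, likely within the scatter and with a slight lean toward a lower number. Compound 4 is therefore estimated at 6 nM, with a range from 2 nM to 25 nM, which corresponds to an expected step of a 1.2-fold lower number from compound 1 to compound 4 (0.07 log units; within the scatter).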

Compound 4, half-maximal inhibitory concentration: 170 nM
Compound 4: the middle estimate sits 28-fold (1.45 log units) below what was measured; measured number outside the range, above it.
By their numbers in this assay, from the lowest: compound 1; then compound 4; then compound 2; then compound 3.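

In this assay, for the compounds shown here, exchanging bromo for iodo on this aromatic carbon brings a 24-fold higher number from compound 1 to compound 4 (1.39 log units; beyond the scatter), the first step in the set that can be read at a single place. It shows that this position is far from indifferent to which halogen it carries: a swap of one heavy atom for one heavy atom, with no ring, hydrogen-bond donor, hydrogen-bond acceptor or net charge entering or leaving, is enough to produce a large change. Nothing shown here explains why these two halogens differ so sharply.

The compounds shown leave open how chloro, methyl or a plain hydrogen at this position would compare with bromo and iodo. They also leave open whether the same exchange would bring a step of similar size at another position on the ring.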